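Pyrazoline thiocarboxamides: aryl swap at the saturated ring carbon

This account rests on a few compounds, and the source may have more. Where it says the series, first, only, none or still open, it means among the compounds named here.

Measured so far in an assay on mitochondria for inhibition of Amine oxidase [flavin-containing] B (Bos taurus); on this read-out higher numbers stand for weaker inhibition and lower numbers for stronger inhibition:
compound 1, `Cc1ccc(C2=NN(C(N)=S)C(c3ccc(Cl)cc3)C2)cc1`, 15 nM
compound 2, `Cc1ccc(C2=NN(C(N)=S)C(c3ccc(C)cc3)C2)cc1`, 10 nM

Within the data shown here, compound 2 gives the lowest of the two numbers in this assay, but its only neighbour, compound 1, sits within the scatter: the step of a 1.5-fold lower number from compound 1 to compound 2 (0.18 log units; within the scatter) is too small to call a difference, so the two compounds are treated as equivalent on this read-out.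

Compound 3, `Cc1ccc(C2=NN(C(N)=S)C(c3ccco3)C2)cc1`, is not yet measured. It differs from compound 2 by furan-2-yl in place of 4-methylphenyl on a saturated ring carbon. Among the measured compounds shown here, no measured step bears directly on this change; the single measured step, from compound 1 to compound 2, only swaps a substituent on that same aryl ring and stays within the scatter, so it says nothing about removing the six-membered ring altogether in favour of furan-2-yl. The change is larger than anything yet measured, and the expectation is therefore wide, leaning toward a somewhat higher number.

For compound 3 the estimate in this assay is 30 nM, with a range of 8 nM to 120 nM. This expected step, a 3.0-fold higher number from compound 2 to compound 3 (0.48 log units; beyond the scatter), rests only on the size of the structural change, not on any measured precedent.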

Compound 3, inhibition constant: 170 nM
The estimate for compound 3 lay 5.7-fold (0.75 log units) below the measured number; the whole stated range lies below it.
By their numbers in this assay, from the lowest: compounds 2 and 1 (each within the scatter of the next); then compound 3.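

In this assay, the saturated ring carbon next to the ring nitrogen proves sensitive to what it carries: furan-2-yl in place of 4-methylphenyl gives a 17-fold higher number from compound 2 to compound 3 (1.23 log units; beyond the scatter) and furan-2-yl in place of 4-chlorophenyl gives an 11-fold higher number from compound 1 to compound 3 (1.05 log units; beyond the scatter) on the same read-out. The chloro-to-methyl swap on the six-membered aromatic ring stayed within the scatter, so tolerance of that swap did not extend to replacing the whole ring with a five-membered aromatic ring that carries an oxygen, and both steps point toward weaker inhibition. No measurement at hand accounts for the size of these steps.

The compounds shown leave open whether the loss belongs to furan-2-yl as such or to the absence of any substituted six-membered ring, a distinction that an unsubstituted phenyl or a thiophen-2-yl at this carbon would help to draw. Also open, as far as these compounds go, is how furan-2-yl behaves with another group, such as 4-methoxyphenyl, on the ring atom that bears the 4-methylphenyl group in all three compounds.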